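A few compounds are considered here, and "the series" means these few. Any claim that something is new, unique, unknown or untested is made for them only; others in the source may bear on it.

In a functional assay, read by spectrophotometry, with a stated time of 6 min (on this read-out higher numbers stand for an effect only at larger amounts of compound and lower numbers for an effect already at smaller amounts), compound 3 `COc1c(C)cc(O)cc1C/C=C(\C)CC(=O)/C=C(\C)CCCC(C)=O` gives 33300 nM. That number lies within the usual scatter of both other measured compounds: compound 1 `COc1c(C)cc(O)cc1/C=C/C(C)(O)CC(=O)/C=C(\C)CCCC(C)C(=O)/C=C/C(C)(C)O` gives 24400 nM and compound 2 `COc1c(C)cc(O)cc1C/C=C(\C)CC(=O)/C=C(/C)CCCC(C)=O` gives 51600 nM. Among the compounds with values here, the only measured step between two closely related compounds is a 1.5-fold lower number from compound 2 to compound 3 (0.19 log units; within the scatter), and it rests on (the fact that compounds 2 and 3 differ only in the configuration as drawn). Within the data shown here, it therefore shows only that this change in double-bond geometry stays within the scatter, and it does not touch the group replaced next.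

Compound 4 `COc1c(C)cc(O)cc1C/C=C(\C)CC(=O)/C=C(\C)CCCC(C)(O)C(=O)/C=C/C(C)(C)O` keeps the core of compound 3, but 1-hydroxy-1-((3-hydroxy-3-methylbut-1-en-1-yl)carbonyl)ethyl stands in place of acetyl on a saturated chain carbon, three bonds along the chain from a double-bonded chain carbon: 1-hydroxy-1-((3-hydroxy-3-methylbut-1-en-1-yl)carbonyl)ethyl in place of acetyl on a saturated chain carbon, three bonds along the chain from a double-bonded chain carbon. Among the measured compounds shown here, no measured step covers this swap. The closest guide is compound 1 at 24400 nM, which also carries a long oxygenated chain and stays within the scatter of compound 3. No step beyond the scatter is therefore expected, and the estimated step is a 1.2-fold lower number from compound 3 to compound 4 (0.09 log units; within the scatter). For compound 4 the expected value is 27000 nM, with an estimated range from 11000 nM to 65000 nM.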

Compound 4, half-maximal effective concentration: 33100 nM
Compound 4: the middle estimate sits 1.2-fold (0.09 log units) below what was measured, within the range that was stated.
By their numbers in this assay, from the lowest: compounds 1, 4, 3 and 2 (each within the scatter of the next, the first and the last beyond it).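

In this assay, putting 1-hydroxy-1-((3-hydroxy-3-methylbut-1-en-1-yl)carbonyl)ethyl in place of acetyl on a saturated chain carbon, three bonds along the chain from a double-bonded chain carbon, gives a 1.0-fold lower number from compound 3 to compound 4 (0.00 log units; within the scatter) in this read-out. The earlier step spoke only of double-bond geometry; this one shows that the position can carry a far larger group, with 11 heavy atoms instead of 3 and 2 hydrogen-bond donors instead of 0, while the two numbers remain within the scatter of each other. Nothing known here explains why the larger group leaves the number within the scatter.

The entering group brings several features at once, so this single step cannot separate their contributions, and opposing effects cannot be ruled out. As far as these compounds go, whether an amine or a carboxylic acid at this place would also stay within the scatter remains open.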